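Pyrimidinyl replacement for the trifluoromethylphenyl ether in the series

The compounds below may be only part of what the source reports. "The series", "measured", "known", "first", "only" and "open" are said of these compounds alone.

The two measured compounds share a core and differ only in the substituent on the benzylic ring of the ether. Compound 1 `Cc1c(C2CC2)nc2ccc(-n3ccc(OCc4ccc(F)cc4)cc3=O)cn12` gives 28 nM in an assay on CHO cells for displacement of a labelled ligand from melanin-concentrating hormone receptor 1 (Rattus norvegicus), read by scintillation counting, with a stated time of 1 h (a lower number here means a stronger inhibitor, a higher number a weaker inhibitor), and compound 2 `Cc1c(C2CC2)nc2ccc(-n3ccc(OCc4ccc(C(F)(F)F)cc4)cc3=O)cn12` gives 82 nM in this assay. Among the compounds with values here, the one measured step, a 2.9-fold higher number from compound 1 to compound 2 (0.47 log units; beyond the scatter), is the only comparison available. Within the data shown here, compound 2 therefore stands as the higher of the two numbers, with compound 1 as its only neighbour.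

Compound 3 `Cc1c(C2CC2)nc2ccc(-n3ccc(OCc4cncnc4)cc3=O)cn12` is the next member, differing from compound 2 by pyrimidin-5-yl in place of 4-(trifluoromethyl)phenyl on a saturated chain carbon bound to an oxygen on an aromatic ring. Among the measured compounds shown here, no measured step in the set bears directly on this change: the step from compound 1 to compound 2 concerns a substituent swap on the same phenyl ring, not the exchange of that ring for a heteroaryl ring, so it gives no size or direction for the present step. The expectation for compound 3 in this assay is accordingly wide and rests on no measured comparison. Compound 3 is estimated at 180 nM, with a range of 40 nM to 900 nM, corresponding to an expected step of a 2.2-fold higher number from compound 2 to compound 3 (0.34 log units; beyond the scatter).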

Compound 3, half-maximal inhibitory concentration: > 1000 nM
Compound 3 was reported as a limit; the forecaster's own chance of this, stated with the estimate: 10%; middle value at least 5.5-fold (0.74 log units) away from the limit.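

In this assay compound 3 is reported only as a limit, not as a number: the limit of > 1000 nM in this assay, at which 1 of the 3 values shown sits. At the saturated chain carbon bound to an oxygen on an aromatic ring, pyrimidin-5-yl in place of 4-(trifluoromethyl)phenyl gives an at least 12-fold higher number from compound 2 to compound 3 (1.08 log units; beyond the scatter), and pyrimidin-5-yl in place of 4-fluorophenyl gives an at least 35-fold higher number from compound 1 to compound 3 (1.55 log units; beyond the scatter). Both steps are large, whereas the change of substituent on the phenyl ring gave a 2.9-fold higher number from compound 1 to compound 2 (0.47 log units; beyond the scatter), so this position is shown for the first time to respond far more strongly to exchange of the ring itself than to the substituent swap seen so far.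

The compounds shown do not separate the effect of the two ring nitrogens from the effect of losing the substituent on the phenyl ring, since pyrimidin-5-yl changes both at once. Going by these compounds, an unsubstituted phenyl or a pyridin-3-yl group at this place would bear on that question, and whether any heteroaryl ring can hold the numbers of compound 1 and compound 2 remains open.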